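Replacing the Aryl Ethenyl Ester of Compound 1 by Acetyl

The compounds below may be only part of what the source reports. "The series", "measured", "known", "first", "only" and "open" are said of these compounds alone.

Compound 1 `COc1ccc(/C=C/C(=O)OC[C@@H](OCc2ccccc2)[C@H]2OC(=O)C=C[C@H]2OCc2ccccc2)cc1` gives 1570 nM.
Compound 2 `CC(=O)O[C@@H]1C=CC(=O)O[C@@H]1[C@@H](COC(=O)/C=C/c1ccc(F)cc1)OC(C)=O` gives 1890 nM.
Compound 3 `CC(=O)O[C@@H]1C=CC(=O)O[C@@H]1[C@@H](COC(=O)/C=C/c1ccc([N+](=O)[O-])cc1)OC(C)=O` gives 4030 nM.

In a functional assay on HL-60 cells (Homo sapiens) for antiproliferative activity, read by MTT assay, with a stated time of 6 days (a higher number here means a weaker inhibitor, a lower number a stronger inhibitor), compound 1 stands at the lowest of the three numbers; compound 2 lies within the scatter of it, compound 3 beyond it. Among the compounds with values here, the only step within the set, a 2.1-fold higher number from compound 2 to compound 3 (0.33 log units; beyond the scatter), swaps nitro for fluoro on an aromatic carbon. Compound 4 `CC(=O)OC[C@@H](OCc1ccccc1)[C@H]1OC(=O)C=C[C@H]1OCc1ccccc1` is not yet measured; it differs from compound 1 by methyl in place of 2-(4-methoxyphenyl)ethenyl on a carbonyl carbon. Within the data shown here, no measured pair removes the aryl-bearing part of the ester, so no step bears directly on this change; that step only shows that a change at the aromatic ring moves the number modestly. Compound 4 is therefore expected to give a higher number, a 2.2-fold higher number from compound 1 to compound 4 (0.35 log units; beyond the scatter). The estimate for compound 4 is 3500 nM, ranging from 1000 nM to 12000 nM.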

Compound 4, half-maximal inhibitory concentration: 9230 nM
Beside the measured number, compound 4's estimate is 2.6-fold (0.42 log units) below it; measured number inside the range.
By their numbers in this assay, from the lowest: compounds 1 and 2 (each within the scatter of the next); then compound 3; then compound 4.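

In this assay, within the data shown here, the first step that removes the aryl-bearing part of the ester, methyl replacing 2-(4-methoxyphenyl)ethenyl on the carbonyl carbon, gives a 5.9-fold higher number from compound 1 to compound 4 (0.77 log units; beyond the scatter). The number therefore depends on what this ester carries, yet a measurable number remains with the plain acetyl, so the activity does not rest on the aryl-bearing part alone. No measurement on hand explains this loss. On these data alone, whether a longer alkyl chain or a simple phenyl on this carbonyl carbon would recover part of the loss stays open. So does whether the same change would cost as much on a core carrying acetyl groups.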